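Thiourea series: tolerance on Vero cells, ethyl to 4-iodophenyl

A few compounds are considered here, and "the series" means these few. Any claim that something is new, unique, unknown or untested is made for them only; others in the source may bear on it.

Compound 1 `CCNC(=S)Nc1cccc(C(F)(F)F)c1` is the reference point of this set. In an ADME assay on Vero 76 cells (Chlorocebus sabaeus) for cytotoxicity, read by crystal violet staining, with a stated time of 96 h (a higher number here means that more compound is tolerated, a lower number that less compound is tolerated), compound 1 gives > 100000 nM. For the measured compounds named here, that value is a limit of the assay and not a number; compound 1 is the one value that sits at the limit of > 100000 nM in this assay, at which 1 of the 3 values shown sits. Two further members of the same core have numbers: compound 2 `CCCCc1ccc(NC(=S)Nc2cccc(C(F)(F)F)c2)c(C)c1` gives 18000 nM in this assay, and compound 3 `Cc1ccc(NC(=S)Nc2cccc(C(F)(F)F)c2)cc1Cl` gives 20000 nM. These two lie within the usual scatter of each other.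

The unmeasured compound 4 `FC(F)(F)c1cccc(NC(=S)Nc2ccc(I)cc2)c1` differs from compound 1 by a single change: 4-iodophenyl in place of ethyl on an amide-type nitrogen. Going by the values given here, no step between measured compounds is available for this change, so the expectation for compound 4 rests on the other two members: compound 2 gives 18000 nM and compound 3 gives 20000 nM, and these show where larger substituents on the shared core fall. The step is expected to go downward, beyond the scatter, to less compound tolerated: an at least 5.0-fold lower number from compound 1 to compound 4 (0.69 log units; beyond the scatter). In this assay compound 4 is estimated at 20000 nM, with a range from 8000 nM to 50000 nM.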

Compound 4, half-maximal cytotoxic concentration: 9500 nM
Estimate against measurement, compound 4: 2.1-fold (0.32 log units) above; the measured number falls inside the stated range.
By their numbers in this assay, from the lowest: compounds 4, 2 and 3 (each within the scatter of the next, the first and the last beyond it). At a limit, above all of these: compound 1.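

For the compounds shown here, replacing ethyl with 4-iodophenyl on an amide-type nitrogen gives the only readable step on the shared core in this assay: an at least 10-fold lower number from compound 1 to compound 4 (1.02 log units; beyond the scatter). Compound 1 gives > 100000 nM, which is a limit of the assay and not a number, so the step has a floor but no fixed size, and compound 1 remains alone at that limit: the limit of > 100000 nM in this assay, at which 1 of the 4 values shown sits. The step shows that tolerance changes beyond the scatter at this nitrogen when a group with no ring gives way to an iodine-bearing six-membered aromatic ring of carbon only, though ring and iodine enter together here.

A plain phenyl at this nitrogen would separate the contribution of the ring from that of the iodine. A longer chain such as hexyl in place of ethyl would test whether a ring is needed for the step at all.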